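The compounds below may be only part of what the source reports. "The series", "measured", "known", "first", "only" and "open" are said of these compounds alone.

Values in a functional assay on NUGC-3 cells (Homo sapiens) for cytotoxicity, read by sulforhodamine B assay, with a stated time of 72 h (a lower number here means a stronger inhibitor of growth, a higher number a weaker inhibitor of growth), for the three measured compounds:

compound 1 `O=C(Nc1ccccc1C(F)(F)F)C1CCc2ccccc2N1C(=O)c1cccc(Cl)c1` gives 754 nM
compound 2 `O=C(Nc1cc(C(F)(F)F)cc(C(F)(F)F)c1)C1CCc2ccccc2N1C(=O)c1ccc(Cl)cc1` gives 1660 nM
compound 3 `O=C(Nc1ccccc1O)C1CCc2ccccc2N1` gives 2680 nM

Compound 2 stands second highest of the three numbers; its nearest neighbour is compound 3, a gap within the scatter, while compound 1 lies beyond the scatter on the lower side. Within the data shown here, no step between any two measured compounds differs in a single place, so no measured step anchors the change to compound 4 `O=C(Nc1cc(C(F)(F)F)cc(C(F)(F)F)c1)C1CCc2ccccc2N1C(=O)c1cccc(Cl)c1`.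

Compound 4 differs from compound 2 only in 3-chlorophenyl in place of 4-chlorophenyl on a carbonyl carbon. The step from compound 2 to compound 4 in this assay is expected to be small, without clear direction, and likely within the scatter: a 1.3-fold lower number from compound 2 to compound 4 (0.11 log units; within the scatter). Compound 4 is estimated at 1300 nM, range 500 nM to 3500 nM.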

Compound 4, concentration for 50% growth inhibition: 560 nM
For compound 4 the middle estimate is 2.3-fold (0.37 log units) above the measured one, within the range that was stated.
By their numbers in this assay, from the lowest: compounds 4 and 1 (each within the scatter of the next); then compounds 2 and 3 (each within the scatter of the next).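

In this assay, 3-chlorophenyl in place of 4-chlorophenyl on the carbonyl carbon gives a 3.0-fold lower number from compound 2 to compound 4 (0.47 log units; beyond the scatter), a modest step beyond the scatter. Among these compounds, this is the first single-place comparison, and it shows that the number responds to where the chlorine sits on this ring, even though the atoms are unchanged. No measurement at hand accounts for the step.

Still open, on these data alone, is whether plain phenyl or a methoxyphenyl on this carbonyl carbon would keep the lower number. Also open, as far as these compounds go, is whether the same step holds with other groups on the amide nitrogen.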